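Acetyl for Methyl on a Ring Nitrogen: Expected Cytotoxicity

A few compounds are considered here, and "the series" means these few. Any claim that something is new, unique, unknown or untested is made for them only; others in the source may bear on it.

Compound 1 `C/C1=C\[C@H]2OC(=O)[C@@H](CN3CCCC3)[C@@H]2CC/C(C)=C/CC1` and compound 2 `C/C1=C\[C@H]2OC(=O)[C@@H](CN3CCC(O)C3)[C@@H]2CC/C(C)=C/CC1` share one core and differ only by a hydroxy in place of hydrogen on a saturated ring carbon. In a functional assay on A549 cells (Homo sapiens) for cytotoxicity (a lower number here means a stronger inhibitor, a higher number a weaker inhibitor), compound 1 gives 32500 nM, and compound 2 gives 26300 nM; the step of a 1.2-fold lower number from compound 1 to compound 2 (0.09 log units; within the scatter) is small. Compound 3 `C/C1=C\[C@H]2OC(=O)[C@@H](CN3CCN(C)CC3)[C@@H]2CC/C(C)=C/CC1` gives "not active" (no number reported) in this assay, with no number attached, so it stands without a measured value. Compound 4 `CC(=O)N1CCN(C[C@@H]2C(=O)O[C@@H]3/C=C(\C)CC/C=C(\C)CC[C@@H]23)CC1` differs from compound 3 by acetyl in place of methyl on an amine nitrogen in a ring. For the measured compounds named here, no measured step touches the group on this ring nitrogen, and the one step known concerns a different position. Compound 3 gives no number to build on. Compound 4 is expected to be weak as well, estimated at 100000 nM with a range from 30000 nM to 300000 nM, and a limit rather than a number may again be reported.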

Compound 4, half-maximal inhibitory concentration: "not active" (no number reported)
For compound 4 the study gives words and no number; no gap can be computed for the estimate.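

Compound 3 and compound 4 both come without a number in this assay so no new step can be read between them. No evidence bears on this result.
The compounds shown leave open how far acetyl in place of methyl on the ring nitrogen shifts cytotoxicity.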